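The source may hold more compounds than are shown below. What is called first, only, known or untested is meant among the compounds shown, and "the series" means these compounds.

Three compounds share one core and differ only in the ring that hangs off the urea. Compound 1 `O=C(Nc1cccc(-n2cc(-c3ccncc3)c(-c3cc(O)cc(Cl)c3)n2)c1)Nc1ccc(Cl)c(C(F)(F)F)c1` carries chloro and trifluoromethyl there; in a functional assay on PC-3 cells (Homo sapiens) for inhibition, read by sulforhodamine B assay, with a stated time of 48 h, tested at 10 uM (on this read-out higher numbers stand for a weaker effect at the one concentration tested and lower numbers for a stronger effect), compound 1 gives 5.34%. Compound 2 `O=C(Nc1cccc(-n2cc(-c3ccncc3)c(-c3cc(O)cc(Cl)c3)n2)c1)Nc1ccc(Cl)c(Cl)c1` carries two chloro groups; in this assay compound 2 gives -1.66%. Compound 3 `COc1cc(Cl)cc(-c2nn(-c3cccc(NC(=O)Nc4cc(C(F)(F)F)cc(C(F)(F)F)c4)c3)cc2-c2ccncc2)c1` carries two trifluoromethyl groups; in this assay compound 3 gives -6.27%, the lowest of the three numbers, within the usual scatter of compound 2 and beyond it only against compound 1.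

Compound 4 `COc1cc(Cl)cc(-c2nn(-c3cccc(NC(=O)Nc4cccc(C(F)(F)F)c4)c3)cc2-c2ccncc2)c1` is compound 3 with one change: hydrogen in place of trifluoromethyl on an aromatic carbon. Among the compounds with values here, the one measured step on this same ring, a number 7 percentage points lower from compound 1 to compound 2 (within the scatter), also swapped one group for another on an aromatic carbon and stayed within the scatter. Within the data shown here, only that step bears here, and it gives no reason to expect a shift beyond the scatter in this assay in either direction; with one trifluoromethyl still present, a number near that of compound 3 is expected. Compound 4 is therefore estimated at -3%, with a range from -15% to 10%. The expected step is a number 3.3 percentage points higher from compound 3 to compound 4 (within the scatter), a step within the scatter.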

Compound 4, a percentage reported as activity, at one concentration (the size of the read-out at that concentration, not a potency): -9.92%
Compound 4: the middle estimate sits 6.9 percentage points above what was measured; the measured number falls inside the stated range.
By their numbers in this assay, from the lowest: compounds 4, 3, 2 and 1 (each within the scatter of the next, the first and the last beyond it).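

In this assay, a number 3.7 percentage points lower from compound 3 to compound 4 (within the scatter) is the first step shown in which a group leaves this ring and nothing heavier than hydrogen takes its place: four heavy atoms go and none enter, whereas the step from chloro and trifluoromethyl to two chloro groups only exchanged one group for another. At this position on the aromatic ring, then, the second trifluoromethyl group can be removed without a shift that stands out from the scatter, although a reading at one concentration says nothing about potency. No measurement shown explains this result.

The compounds shown leave open whether this carbon would accept a group of a different kind, such as an amine or a carboxylic acid, as readily as it accepts hydrogen, and whether the ring would give a similar reading with the remaining trifluoromethyl group replaced by hydrogen as well. They also leave open whether the same change would give a similar step on the hydroxy-bearing core of compound 1, since this step was read only on the methoxy-bearing core of compound 3.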